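A few compounds are considered here, and "the series" means these few. Any claim that something is new, unique, unknown or untested is made for them only; others in the source may bear on it.

Measured in a functional assay on HT-29 cells (Homo sapiens) for inhibition, read by luminescence and CellTiter-Glo, with a stated time of 24 h; on this read-out higher numbers stand for an effect only at larger amounts of compound and lower numbers for an effect already at smaller amounts:
compound 1 `CN1C(=S)[C@@H](NC(=O)c2nc(Cc3ccccc3)n(C3CCC3)n2)COc2ccccc21` gives 181 nM
compound 2 `CN1C(=S)[C@@H](NC(=O)c2nc(Cc3ccccc3)n(C3CCN(C(=O)OC(C)(C)C)CC3)n2)COc2ccccc21` gives > 10000 nM, which is a limit of the assay and not a number.

Compound 1 thus holds the only number shown in this assay, the other value being a limit. For compound 2 the record is the limit of > 10000 nM in this assay, at which 1 of the 2 values shown sits, and nothing more can be said of it. Compound 3 `CN1C(=S)[C@@H](NC(=O)c2nc(Cc3ccccc3)n(-c3ncccn3)n2)COc2ccccc21` has not yet been measured. It differs from compound 1 by pyrimidin-2-yl in place of cyclobutyl on an aromatic nitrogen. Among the measured compounds shown here, no step between two measured compounds is available, so neither size nor direction of the change from compound 1 to compound 3 can be read off from existing pairs. What the data do show is that one change on the core, in compound 2, removes the effect entirely within the tested range, so compound 3 may also lose potency. Compound 3 is therefore expected at 600 nM, within a range of 120 nM to 5000 nM. This estimate means a step of a 3.3-fold higher number from compound 1 to compound 3 (0.52 log units; beyond the scatter), a loss expected to lie somewhat beyond the usual scatter, with a real chance that only a limit is reported.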

Compound 3, half-maximal effective concentration: 3970 nM
Estimate against measurement, compound 3: 6.6-fold (0.82 log units) below; the measured number falls inside the stated range.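

In this assay, exchanging cyclobutyl for pyrimidin-2-yl on an aromatic nitrogen of the five-membered ring gives a 22-fold higher number from compound 1 to compound 3 (1.34 log units; beyond the scatter), the first size that can be read for any change at this position. The step shows that the effect depends strongly on the group at this nitrogen, yet compound 3, with its six-membered aromatic ring bearing 2 hetero atoms, still gives a number within the tested range. Compound 2, which carries another group at the same nitrogen, stands only at a limit of the assay and not at a number: the limit of > 10000 nM in this assay, at which 1 of the 3 values shown sits.

The exchange alters ring size, aromatic character and the count of ring nitrogens all at once, so the compounds shown cannot assign the loss to any one of these. They leave open how cyclopentyl, phenyl with carbon only in its ring, or an open chain such as isobutyl would stand at this nitrogen, and whether a pyridin-2-yl group would fall nearer to compound 1 or to compound 3.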